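From Iodomethyl to Hydroxymethyl on a Shared Core

This account rests on a few compounds, and the source may have more. Where it says the series, first, only, none or still open, it means among the compounds named here.

Compound 1, `COCC1=CS(=O)(=O)c2ccccc2C1=O`, gives 99.9% in a functional assay on the whole organism for inhibition, with Mus musculus as the target, at a dose of 10 mg/kg; a higher number here means more inhibition at the dose given (going by the name of the read-out), a lower number less inhibition.
Compound 2, `CCCOCC1=CS(=O)(=O)c2ccccc2C1=O`, gives 99.9% in this assay.
Compound 3, `O=C1C(CI)=CS(=O)(=O)c2ccccc21`, gives 98% in this assay.

Compound 3 has the lowest of the three numbers, yet the gaps are small: a number 1.9 percentage points lower from compound 1 to compound 3 (within the scatter) and a number 1.9 percentage points lower from compound 2 to compound 3 (within the scatter), both within the scatter. All three compounds therefore sit at essentially the same high inhibition.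

Compound 4, `O=C1C(CO)=CS(=O)(=O)c2ccccc21`, has not yet been measured. It differs from compound 3 in one place: hydroxy in place of iodo on a saturated chain carbon bound to a double-bonded ring carbon.

Going by the values given here, no measured step introduces a hydroxy group. Among the compounds with values here, the steps that bear on this one are the swaps at the same saturated chain carbon, a number 1.9 percentage points lower from compound 1 to compound 3 (within the scatter) and a number 1.9 percentage points lower from compound 2 to compound 3 (within the scatter), and the chain extension no change at the digits printed from compound 1 to compound 2 (within the scatter); none of them moved the number beyond the scatter. The expectation for compound 4 in this assay is therefore no step beyond the scatter, a number 1 percentage points lower from compound 3 to compound 4 (within the scatter).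

Compound 4 is expected to give about 97%, within a range from 85% to 99.9%.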

Compound 4, a percentage reported as inhibition, in the whole organism at one dose (the size of the read-out at that dose, not a potency): 99.3%
Compound 4: middle estimate off by 2.3 percentage points, on the low side; low and high end bracket the measured number.
By their numbers in this assay, from the lowest: compounds 3, 4, 1 and 2 (each within the scatter of the next).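

At this saturated chain carbon bound to a double-bonded ring carbon, hydroxy brings a hydrogen-bond donor that none of the earlier groups carried, and in this assay the swap from iodo gives a number 1.3 percentage points higher from compound 3 to compound 4 (within the scatter) without leaving the high range. Whether the oxygen on this chain carbon carries a hydrogen or an alkyl group also makes no readable difference, with hydrogen in place of propyl giving a number 0.6 percentage points lower from compound 2 to compound 4 (within the scatter) and hydrogen in place of methyl giving a number 0.6 percentage points lower from compound 1 to compound 4 (within the scatter) in this assay. Nothing available explains why these groups read alike.

As far as these compounds go, what an amine or a carboxylic acid on this chain carbon would give remains open. So does whether the four compounds would still read alike at a lower dose, since a single dose near the top of a percentage scale leaves little room to separate them.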